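The source may report more compounds than this note shows. Statements on the series, on what has been measured and on what is new or still open speak of the compounds shown alone.

Compound 1 `NS(=O)(=O)c1ccc(Nc2nc(N/N=C/c3ccc(C(F)(F)F)cc3)nc(Nc3ccccc3)n2)cc1` carries a 4-(trifluoromethyl)phenyl on the carbon with a double bond to nitrogen, and in a functional assay on HCT-116 cells (Homo sapiens) for inhibition, read by sulforhodamine B assay, with a stated time of 48 h (a higher number here means that more compound is tolerated, a lower number that less compound is tolerated), compound 1 gives 64000 nM. Compound 2 `Cc1nn(-c2ccccc2)cc1/C=N/Nc1nc(Nc2ccccc2)nc(Nc2ccc(S(N)(=O)=O)cc2)n1` bears a 3-methyl-1-phenyl-1H-pyrazol-4-yl in that place. In this assay compound 2 reaches only a limit of the assay, > 100000 nM, so its standing on the numbers is a floor and not a point (the limit of > 100000 nM in this assay, at which 1 of the 2 values shown sits). The step of an at least 1.5-fold higher number from compound 1 to compound 2 (0.19 log units; that floor lies within the scatter) is therefore only a floor, and that floor lies within the scatter, so the two aryl exchanges so far have not resolved a difference.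

Compound 3 `NS(=O)(=O)c1ccc(Nc2nc(N/N=C/c3ccccn3)nc(Nc3ccccc3)n2)cc1` differs from compound 2 by pyridin-2-yl in place of 3-methyl-1-phenyl-1H-pyrazol-4-yl on a carbon with a double bond to nitrogen. Going by the values given here, the one measured step that bears on it, the exchange of the aryl group on the same carbon from compound 1 to compound 2, was too small to separate from the scatter. Nothing in the numbers therefore points to a step beyond the scatter in this assay in either direction, and the whole series sits at or near the limit. Compound 3 is accordingly expected at about 90000 nM, within a range of 40000 nM to 200000 nM, which means an expected step of an at least 1.1-fold lower number from compound 2 to compound 3 (0.04 log units; that floor lies within the scatter).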

Compound 3, concentration lethal to 50% of the cells: > 100000 nM
Compound 3 gave a limit, no number; the forecaster's own chance of this, stated with the estimate: 50%; middle value at least 1.1-fold (0.04 log units) away from the limit.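

Exchanging the 3-methyl-1-phenyl-1H-pyrazol-4-yl for pyridin-2-yl on the carbon with a double bond to nitrogen removes one of the two rings, yet the reading in this assay stays at the limit, so two different groups at this position now end there and the step between them cannot be read. Set against the 4-(trifluoromethyl)phenyl, pyridin-2-yl gives an at least 1.5-fold higher number from compound 1 to compound 3 (0.19 log units; that floor lies within the scatter), so this exchange, like the earlier one, resolves no difference. The readings at this position now gather at a single point: the limit of > 100000 nM in this assay, at which 2 of the 3 values shown sit.

As far as these compounds go, how far compound 2 and compound 3 truly lie from each other remains open, and so does whether any group on this carbon can move the number beyond the scatter. Whether a phenyl ring bearing a carboxylic acid or an amine, or a longer alkyl chain in place of the aromatic ring, would give a number clearly lower than that of compound 1 is not settled by the compounds shown.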